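A few compounds are considered here, and "the series" means these few. Any claim that something is new, unique, unknown or untested is made for them only; others in the source may bear on it.

Measured compounds:
- Compound 1, `COc1cc(-c2nnc3n2NC(c2ccco2)C(C(=O)c2ccc(C)cc2)S3)cc(OC)c1OC`: > 100000 nM in a functional assay on MCF7 cells (Homo sapiens) for cytotoxicity, read by MTT assay, with a stated time of 48 h; a higher number here means a weaker inhibitor, a lower number a stronger inhibitor
- Compound 2, `COc1cc(-c2nnc3n2NC(c2ccco2)C(C(=O)c2ccc(F)c(F)c2)S3)cc(OC)c1OC`: 73200 nM in this assay

For the measured compounds named here, compound 2 holds the only numerical value in this assay; the other entry is a limit. For compound 1 the assay reports only a limit, namely (the limit of > 100000 nM in this assay, at which 1 of the 2 values shown sits). Going by the values given here, the single measured step between these two is an at least 1.3-fold lower number from compound 1 to compound 2 (0.13 log units; that floor lies within the scatter), and its floor does not rise beyond the usual scatter, so the two compounds cannot be ranked against each other.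

Compound 3, `COc1cc(-c2nnc3n2NC(c2ccco2)C(C(=O)c2ccco2)S3)cc(OC)c1OC`, keeps the shared core and changes the group on the carbonyl carbon: furan-2-yl in place of 3,4-difluorophenyl on a carbonyl carbon. Among the compounds with values here, no measured step exchanges this aryl group for a furan-2-yl, so the only guide is that the earlier exchange at the same carbonyl carbon, from compound 1 to compound 2, produced no change that clears the scatter. On that basis the step of a 1.0-fold higher number from compound 2 to compound 3 (0.01 log units; within the scatter) is expected to stay within the scatter as well, in no particular direction. Compound 3 is therefore estimated at 75000 nM in this assay, with a range from 25000 nM to 200000 nM.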

Compound 3, half-maximal inhibitory concentration: > 100000 nM
Compound 3: only a limit was reported; the forecaster's own chance of this, stated with the estimate: 35%; middle value at least 1.3-fold (0.12 log units) from the limit.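

A third kind of ring now sits on the carbonyl carbon, and in this assay compound 3 gives only a limit, > 100000 nM. For the compounds shown here, measured against the one numerical value, the exchange of 3,4-difluorophenyl for furan-2-yl is an at least 1.3-fold higher number from compound 2 to compound 3 (0.13 log units; that floor lies within the scatter), so a five-membered aromatic ring with a hetero atom cannot be ranked against the fluorinated six-membered ring at this position. The step between compound 1 and compound 3 cannot be read, and the series now rests mostly on limits rather than numbers: the limit of > 100000 nM in this assay, at which 2 of the 3 values shown sit.

On these data alone, what stays open is whether any group on this carbonyl carbon can bring the number clearly down, for instance a pyridine ring, a phenyl ring carrying an amine or a carboxylic acid, or an open chain such as butyl in place of a ring. The shared core is also the same in all three compounds, so these results say nothing about how changes elsewhere in the molecule would read in this assay.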